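Chloro for methyl on the anilide of compound 3

This account rests on a few compounds, and the source may have more. Where it says the series, first, only, none or still open, it means among the compounds named here.

Measured in a functional assay on A549 cells (Homo sapiens) for antiproliferative activity, read by MTT assay, with a stated time of 72 h; a higher number here means a weaker inhibitor, a lower number a stronger inhibitor:
- compound 1 `Cc1ccc(-c2noc(CCCCCCC(=O)NO)n2)cc1`: 5810 nM
- compound 2 `COc1ccc(-c2noc(CCCCCCC(=O)NO)n2)cc1`: 13500 nM
- compound 3 `Cc1ccc(-c2noc(CCCCCCC(=O)Nc3ccccc3N)n2)cc1`: 9170 nM

Compound 3 lies within the scatter of both compound 1 and compound 2. Compound 4 `Nc1ccccc1NC(=O)CCCCCCc1nc(-c2ccc(Cl)cc2)no1` carries chloro in place of methyl on an aromatic carbon, para to a large group (chloro in place of methyl on an aromatic carbon). Chloro itself has not been measured in this series. Among the measured compounds shown here, the only measured change at that place, methoxy in place of methyl, gave a 2.3-fold higher number from compound 1 to compound 2 (0.37 log units; beyond the scatter). Replacing hydroxy with 2-aminophenyl on the amide-type nitrogen gave a 1.6-fold higher number from compound 1 to compound 3 (0.20 log units; within the scatter). The expected step is a 1.1-fold lower number from compound 3 to compound 4 (0.06 log units; within the scatter), with none expected beyond the scatter. For compound 4 the estimated value in this assay is 8000 nM, with an expected range of 3500 nM to 17000 nM.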

Compound 4, half-maximal inhibitory concentration: 13800 nM
The estimate for compound 4 lay 1.7-fold (0.24 log units) below the measured number, within the range that was stated.
By their numbers in this assay, from the lowest: compounds 1, 3, 2 and 4 (each within the scatter of the next, the first and the last beyond it).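

In this assay, chloro in place of methyl gives a 1.5-fold higher number from compound 3 to compound 4 (0.18 log units; within the scatter), so with 2-aminophenyl on the amide-type nitrogen this exchange on the aromatic carbon leaves the number within the scatter. Among the compounds shown here, the only earlier change at this place, methoxy in place of methyl, was read with hydroxy on that nitrogen, so this is the first reading at this place with 2-aminophenyl there. No supporting evidence bears on this result.

As far as these compounds go, whether an amine or a carboxylic acid at this place would give a step beyond the scatter remains open. Also open, from the compounds shown here alone, is how chloro reads with hydroxy on the amide-type nitrogen.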